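Swapping the chain end on a potent chain-linked acid

The source may report more compounds than this note shows. Statements on the series, on what has been measured and on what is new or still open speak of the compounds shown alone.

Measured so far in a functional assay on ileum (Cavia porcellus) for antagonist activity, with a stated time of 30 s; on this read-out lower numbers stand for stronger inhibition and higher numbers for weaker inhibition:
- compound 1 `O=C(O)c1cc(=O)c2c(OCCCCCOc3ccccc3)cccc2o1`: 17.5 ug/mL
- compound 2 `O=C(O)c1cc(=O)c2ccc(OCCCCCSc3ccccc3)cc2o1`: 0.4 ug/mL
- compound 3 `O=C(O)c1cc(=O)c2ccc(SCCCCCOc3ccccc3)cc2o1`: 0.3 ug/mL

Among these three, compound 2 stands at 0.4 ug/mL, within the scatter of compound 3 at 0.3 ug/mL. The two form a low-number pair, and compound 1 lies well apart from them at 17.5 ug/mL, a gap beyond the scatter.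

Among the measured compounds shown here, the next compound to be tested in this assay is compound 4 `COc1cccc(OCCCCCOc2ccc3c(=O)cc(C(=O)O)oc3c2)c1`, which has no measurement yet. Its structure departs from that of compound 2 in one place: 3-methoxyphenoxy in place of phenylsulfanyl on a saturated chain carbon, five bonds along the chain from an oxygen on an aromatic ring.

For the measured compounds named here, no measured pair isolates this change, so the expectation rests on indirect evidence. Compound 3 at 0.3 ug/mL carries an oxygen at the ring end of its chain, where compound 2 has sulfur, and its value stays within the scatter of compound 2. No step beyond the scatter is therefore expected in this assay, with at most a slight drift toward weaker inhibition. On these data alone, the added methoxy is untested in this set, so the upper end of the range is left wide.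

The estimated change is a 1.3-fold higher number from compound 2 to compound 4 (0.10 log units; within the scatter). For compound 4 the expected value is 0.5 ug/mL, with an estimated range from 0.15 ug/mL to 1.8 ug/mL.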

Compound 4, half-maximal inhibitory concentration: 1.5 ug/mL
Compound 4: the middle estimate sits 3.0-fold (0.48 log units) below what was measured; measured number inside the range.
By their numbers in this assay, from the lowest: compounds 3 and 2 (each within the scatter of the next); then compound 4; then compound 1.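

In this assay, the exchange of phenylsulfanyl for 3-methoxyphenoxy gives a 3.8-fold higher number from compound 2 to compound 4 (0.57 log units; beyond the scatter), a modest step but one beyond the usual scatter, so what sits at this place on the chain does affect inhibition. The exchange keeps the six-membered aromatic ring of carbon only and the absence of net charge, while the entering group has 9 heavy atoms against 7 and 2 hydrogen-bond acceptors against 1, and this combined change goes with weaker inhibition. Nothing available here bears on why the number rises.

The step joins two changes in one, the loss of the sulfur and the arrival of the methoxy, and a version of compound 2 with plain phenoxy in place of phenylsulfanyl would separate them. The compounds shown also leave open how other groups on the same aromatic ring at this chain end, such as a fluoro group, a hydroxy group or an amine, would read out, and whether a longer chain would change the size of this step.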